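Phenyl for cyclohexyl across two related cores

The compounds below may be only part of what the source reports. "The series", "measured", "known", "first", "only" and "open" are said of these compounds alone.

Compound 1 `Cc1ccc(S(=O)(=O)N2CC[C@@H](Br)C[C@@H]2C2CCCCC2)cc1` and compound 2 `Cc1ccc(S(=O)(=O)N2CC[C@@H](Br)C[C@@H]2c2ccccc2)cc1` share one core. In a functional assay on SW1573 cells (Homo sapiens) for antiproliferative activity, read by sulforhodamine B assay, with a stated time of 48 h (on this read-out higher numbers stand for weaker inhibition of growth and lower numbers for stronger inhibition of growth), compound 1 gives 82000 nM. For compound 2 this assay reports only a limit, > 100000 nM. The change between them, (phenyl in place of cyclohexyl on a saturated ring carbon), makes an at least 1.2-fold higher number from compound 1 to compound 2 (0.08 log units; that floor lies within the scatter); the step has a floor only because of the limit of > 100000 nM in this assay, at which 1 of the 3 values shown sits.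

Compound 3 `Cc1ccc(S(=O)(=O)N2CCC(Cl)=CC2C2CCCCC2)cc1` rests on a different core; the difference between the two cores is not broken down here. In this assay compound 3 gives 62000 nM.

Compound 4 `Cc1ccc(S(=O)(=O)N2CCC(Cl)=CC2c2ccccc2)cc1` is not yet measured. It stands to compound 3 as compound 2 stands to compound 1: phenyl in place of cyclohexyl on a saturated ring carbon. Around the place, the only difference in words is that compound 3 carries a chloro group where compound 1 carries a bromo group, so the change is of the same kind, not the same.

For the measured compounds named here, the step from compound 3 to compound 4 in this assay is expected as a 1.6-fold higher number from compound 3 to compound 4 (0.21 log units; within the scatter), placed beside an at least 1.2-fold higher number from compound 1 to compound 2 (0.08 log units; that floor lies within the scatter) as its only precedent. For compound 4 the estimate is 100000 nM, between 55000 nM and 200000 nM, with a fair chance that the assay again reports only a limit.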

Compound 4, concentration for 50% growth inhibition: 16000 nM
The estimate for compound 4 lay 6.3-fold (0.80 log units) above the measured number; measured number outside the range, below it.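

In this assay, phenyl in place of cyclohexyl on a saturated ring carbon gives a 3.9-fold lower number from compound 3 to compound 4 (0.59 log units; beyond the scatter), so on these compounds the change does not carry over from the core of compound 1 to the core of compound 3 in direction: the same change on two cores in this assay, an at least 1.2-fold higher number (0.08 log units; that floor lies within the scatter) from compound 1 to compound 2 and a 3.9-fold lower number (0.59 log units; beyond the scatter) from compound 3 to compound 4, at least 4.7-fold (0.67 log units) apart, beyond the scatter of two such steps. As far as these compounds go, the comparison rests on one pair for each core, and one side of it is open-ended, as compound 2 is reported only as a limit: the limit of > 100000 nM in this assay, at which 1 of the 4 values shown sits. The two pairs do not show which difference between the cores separates the steps, nor do they show that the lower number seen with compound 4 would appear on any further core.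

The compounds shown leave open whether the chloro group or the rest of the core decides the outcome of the change. They also leave open how an amine, a carboxylic acid or a longer alkyl chain in place of phenyl or cyclohexyl at the same ring carbon would read on either core.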